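This account rests on a few compounds, and the source may have more. Where it says the series, first, only, none or still open, it means among the compounds named here.

Of the compounds shown here, three that share one core have been tested in an assay on brain for binding affinity to Neuronal acetylcholine receptor; alpha4/beta2 (Rattus norvegicus), read by radioligand binding; a lower number here means a stronger inhibitor, a higher number a weaker inhibitor. Compound 1 `Brc1ccc(OC[C@@H]2CCN2)cn1` gives 0.021 nM, and compound 3 `Fc1cncc(OC[C@@H]2CCN2)c1` gives 0.076 nM, the second highest of the three numbers, while compound 2 `CCc1ccc(OC[C@@H]2CCN2)cn1` gives 19 nM. Among the measured compounds shown here, the only step measured so far, a 900-fold higher number from compound 1 to compound 2 (2.96 log units; beyond the scatter), changes a group at a place other than the one varied here. Compound 4 `Nc1cncc(OC[C@@H]2CCN2)c1` differs from compound 3 by amino in place of fluoro on an aromatic carbon. For the measured compounds named here, no measured step exchanges fluoro for amino, so that single step is a weak guide, and the expected change in this assay is a modest weakening, a 6.6-fold higher number from compound 3 to compound 4 (0.82 log units; beyond the scatter). Compound 4 is therefore estimated at 0.5 nM, between 0.1 nM and 3 nM.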

Compound 4, inhibition constant: 0.082 nM
For compound 4 the middle estimate is 6.1-fold (0.79 log units) above the measured one; measured number below the stated range.
By their numbers in this assay, from the lowest: compound 1; then compounds 3 and 4 (each within the scatter of the next); then compound 2.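

In this assay, putting amino in place of fluoro on this aromatic carbon gives a 1.1-fold higher number from compound 3 to compound 4 (0.03 log units; within the scatter), so compound 3 and compound 4 cannot be told apart. This position therefore accepts both groups alike in this assay, even though amino brings a hydrogen-bond donor and a hydrogen-bond acceptor that fluoro lacks. No measured evidence is available to explain this match. Only these two small groups are shown at this position, so a larger group such as a carboxylic acid, a methoxy or a longer chain remains an open question.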